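Chlorophenyl sulfonyl positional swap in a pyrrolopyridine series

A few compounds are considered here, and "the series" means these few. Any claim that something is new, unique, unknown or untested is made for them only; others in the source may bear on it.

Compound 1 `CN1CCC(n2cc(S(=O)(=O)c3ccc(F)cc3)c3cccnc32)C1` and compound 2 `CN1CCC(n2cc(S(=O)(=O)c3cccc(Cl)c3)c3cccnc32)C1` share one core and differ only in the aryl group on the sulfonyl sulfur. In a functional assay on HeLa cells for antagonist activity at 5-hydroxytryptamine receptor 6 (Homo sapiens), read by cAMP accumulation and immunoassay (a higher number here means a larger maximal response, a lower number a smaller maximal response), compound 1 gives 85% and compound 2 gives 85%; the step of no change at the digits printed from compound 1 to compound 2 (within the scatter) shows that exchanging the halogenated aryl group here left the maximal response unchanged. Compound 2 thus stands level with compound 1 on the numbers at hand. Compound 3 `CN1CCC(n2cc(S(=O)(=O)c3ccc(Cl)cc3)c3cccnc32)C1` is not yet measured; it differs from compound 2 in one place: 4-chlorophenyl in place of 3-chlorophenyl on a sulfonyl sulfur. For the measured compounds named here, only the step from compound 1 to compound 2 bears on this change, and it was flat within the scatter, so no step beyond the scatter is expected in this assay for the move from compound 2 to compound 3, that is an expected no change at the digits printed from compound 2 to compound 3 (within the scatter). Compound 3 is therefore expected to give about 85%, in the range 70% to 100%.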

Compound 3, largest response reached (reported as percent of maximum), in percent of the reference or control that the assay uses: 98%
Compound 3: middle estimate off by 13 percentage points, on the low side; the range from low to high includes it.
By their numbers in this assay, from the lowest: compounds 1 and 2 (each within the scatter of the next); then compound 3.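

In this assay the place of the chlorine on the aryl group matters: 4-chlorophenyl in place of 3-chlorophenyl on a sulfonyl sulfur gives a number 13 percentage points higher from compound 2 to compound 3 (beyond the scatter), a modest step that the earlier pair could not reveal. The halogen matters as well, since chloro in place of fluoro on an aromatic carbon gives a number 13 percentage points higher from compound 1 to compound 3 (beyond the scatter), so the flat step between the first two compounds, which changed halogen and place together, did not mean that this aryl group is insensitive to change. Nothing at hand accounts for either step.

On these data alone, it remains open whether the trend continues with bromo or methoxy in place of chloro on the aryl group, or with an unsubstituted phenyl. As far as these compounds go, whether either step holds on a core with a different group on the ring nitrogen, such as an ethyl in place of the methyl, also remains open.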